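The source may report more compounds than this note shows. Statements on the series, on what has been measured and on what is new or still open speak of the compounds shown alone.

The measured compounds and their values:

Compound 1 `CCCn1nc(S(=O)(=O)c2cccc3ccccc23)c2cc(N3CCNCC3)ccc21`: 99%
Compound 2 `CN1CCN(c2ccc3[nH]nc(S(=O)(=O)c4ccc(F)cc4)c3c2)CC1`: 98%
Compound 3 `CN1CCN(c2cccc3c(S(=O)(=O)c4cccc5ccccc45)n[nH]c23)CC1`: 100%

All three compounds were examined in a functional assay on HeLa cells for antagonist activity at 5-hydroxytryptamine receptor 6 (Homo sapiens); on this read-out lower numbers stand for smaller maximal responses and higher numbers for larger maximal responses. In this assay compound 1 gives 99%, compound 2 gives 98% and compound 3 gives 100%. The three numbers sit close to the full response of the control, and each of them lies within the usual scatter of the other two, so the values of compound 2, compound 1 and compound 3 cannot be told apart on these data. Among the compounds with values here, no step between two measured compounds that differ in a single place is available here, so no measured change of a group can be drawn on.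

Compound 4 `COc1ccc(S(=O)(=O)c2n[nH]c3ccc(N4CCN(C)CC4)cc23)cc1` has not yet been measured in this assay. It differs from compound 2 in one place: methoxy in place of fluoro on an aromatic carbon. Since the three measured compounds, with differing sulfonyl aryl groups and differing cores, all reach nearly the same maximal response, the step from compound 2 to compound 4 is expected to be no change at the digits printed from compound 2 to compound 4 (within the scatter), that is, no change beyond the scatter in either direction. For compound 4 the estimated maximal response in this assay is 98%, in a range from 88% to 104%.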

Compound 4, largest response reached (reported as Imax), in percent of the reference or control that the assay uses: 100%
Compound 4: middle estimate off by 2 percentage points, on the low side, and the stated range covers the measured number.
By their numbers in this assay, from the lowest: compounds 2, 1, 3 and 4 (each within the scatter of the next).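

Within the data shown here, this pair gives the only single-place comparison in the set: in this assay, the change from 4-fluorophenyl to 4-methoxyphenyl gives a number 2 percentage points higher from compound 2 to compound 4 (within the scatter). The earlier compounds shown here differed from one another in more than one place, so their similar values could not show what this position tolerates on its own. Here, on an aromatic carbon para to a large group, methoxy, with 2 heavy atoms and 1 hydrogen-bond acceptor, stands in place of fluoro, with 1 heavy atom and no hydrogen-bond acceptor, and the maximal response of the two compounds cannot be told apart. Nothing available here accounts for this outcome.

The compounds shown leave open whether an amine, a carboxylic acid or a longer chain such as butoxy at this same position would also remain within the scatter of compound 2. They also leave open whether the change from fluoro to methoxy would read the same on the core of compound 1 or compound 3, since this single step comes from the core shared by compound 2 and compound 4.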